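This account rests on a few compounds, and the source may have more. Where it says the series, first, only, none or still open, it means among the compounds named here.

In a functional assay on PANC-1 cells (Homo sapiens) for cytotoxicity, read by MTT assay, with a stated time of 72 h (on this read-out lower numbers stand for stronger inhibition and higher numbers for weaker inhibition), three compounds sharing a core have been measured: compound 1 `COc1cc(NC2=CC(=O)c3ncncc3C2=O)cc(OC)c1` gives 7200 nM, compound 2 `Nc1ccc(-c2ccc(NC3=CC(=O)c4ncncc4C3=O)cc2)cc1` gives 3700 nM and compound 3 `O=C1C(NCc2ccc(F)cc2)=CC(=O)c2ncncc21` gives 1000 nM. Compound 2 sits at the weaker end of this small set: its number lies within the scatter of compound 1, and it is higher than compound 3 by more than the scatter. Compound 4 `O=C1C(Nc2ccc(CO)cc2)=CC(=O)c2ncncc21` has hydroxymethyl in place of 4-aminophenyl on an aromatic carbon. Within the data shown here, no measured pair shows what this change does, so the expectation starts from compound 2 at 3700 nM. The expected step, a 1.2-fold lower number from compound 2 to compound 4 (0.09 log units; within the scatter), is none beyond the scatter in this assay. For compound 4 the estimated value is 3000 nM, with an expected range of 1000 nM to 9000 nM.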

Compound 4, half-maximal inhibitory concentration: 1000 nM
Beside the measured number, compound 4's estimate is 3.0-fold (0.48 log units) above it, within the range that was stated.
By their numbers in this assay, from the lowest: compounds 3 and 4 (each within the scatter of the next); then compounds 2 and 1 (each within the scatter of the next).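

Replacing 4-aminophenyl with hydroxymethyl on this aromatic carbon, para to a large group, gives a 3.7-fold lower number from compound 2 to compound 4 (0.57 log units; beyond the scatter) in this assay. Among these compounds, this is the first measured change at this position, and it shows that the outer carbon ring is not needed for this level of activity, even though the smaller group keeps the same counted hydrogen-bond donor and acceptor. Nothing available explains why the number falls. From the compounds shown here alone, it remains open whether a carboxylic acid, an aminomethyl group or a longer chain ending in hydroxyl would do the same here.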